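Swapping fluoro for chloro on a sulfone-bearing aryl ring

The source may report more compounds than this note shows. Statements on the series, on what has been measured and on what is new or still open speak of the compounds shown alone.

Compound 1 `O=S(=O)(/C=C/c1ccccn1)c1ccc(F)cc1`: 3100 nM
Compound 2 `O=S(=O)(/C=C\c1ncccc1Cl)c1cccc(F)c1`: 2160 nM
Compound 3 `O=S(=O)(/C=C\c1ncccc1Cl)c1cccc(Cl)c1`: 290 nM

Of the compounds shown here, three have been measured in an assay on U2OS cells for activation of nuclear factor erythroid 2-related factor 2 (Homo sapiens), read by beta-arrestin recruitment, with a stated time of 6 h; on this read-out lower numbers stand for an effect already at smaller amounts and higher numbers for an effect only at larger amounts of compound. Compound 1 gives 3100 nM, compound 2 gives 2160 nM and compound 3 gives 290 nM. Compounds 1 and 2 differ in their cores, and that difference is not broken down here; their two values lie within the usual scatter of each other. Compound 2 and compound 3 share a core and differ only by chloro in place of fluoro on an aromatic carbon, and that change brought a 7.4-fold lower number from compound 2 to compound 3 (0.87 log units; beyond the scatter).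

Compound 4 `O=S(=O)(/C=C/c1ccccn1)c1ccc(Cl)cc1` has not yet been measured in this assay. It relates to compound 1 by chloro in place of fluoro on an aromatic carbon. This is the same kind of change as that from compound 2 to compound 3, with one difference in where it sits: on the core of compound 1 the carbon is para to a large group, while on the core of compound 2 it is meta to a large group.

Because the step of a 7.4-fold lower number from compound 2 to compound 3 (0.87 log units; beyond the scatter) was clearly beyond the scatter, a step of similar direction is expected for compound 4, though it may be somewhat smaller given the different place. Compound 4 is expected to give 650 nM, between 250 nM and 1700 nM, meaning an estimated step of a 4.8-fold lower number from compound 1 to compound 4 (0.68 log units; beyond the scatter).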

Compound 4, half-maximal effective concentration: 1730 nM
Estimate against measurement, compound 4: 2.7-fold (0.43 log units) below, outside the stated range (above it).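

In this assay chloro in place of fluoro on the core of compound 1 gives a 1.8-fold lower number from compound 1 to compound 4 (0.25 log units; within the scatter) and so leaves these two compounds not clearly apart, while the same swap on the core of compound 2 gave a clear step, and the two steps differ: the same change on two cores in this assay, a 7.4-fold lower number (0.87 log units; beyond the scatter) from compound 2 to compound 3 and a 1.8-fold lower number (0.25 log units; within the scatter) from compound 1 to compound 4, 4.2-fold (0.62 log units) apart, beyond the scatter of two such steps. This shows that the size of the step seen on one core cannot simply be carried over to another core in this series. It does not show which difference between the two pairs is responsible, whether the cores themselves or the place of the swap on the ring, and two pairs are too few to tell.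

On these data alone, whether a group other than these two halogens, such as a methoxy group or an amine, on the same aromatic carbon would give a clear step on the core of compound 1 stays open. Also open, as far as these compounds go, is how chloro in place of fluoro behaves on any further core.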